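Sulfonyl amine swap, compound 1 to compound 3

The source may hold more compounds than are shown below. What is called first, only, known or untested is meant among the compounds shown, and "the series" means these compounds.

Measured so far:
Compound 1 `Cc1ccc(S(=O)(=O)N2CCN(C)CC2)cc1C#Cc1cc(Cl)ccc1OCC(=O)O`: in an assay on CHO cells for displacement of a labelled ligand from prostaglandin D2 receptor 2 (Homo sapiens), read by scintillation counting (on this read-out higher numbers stand for weaker inhibition and lower numbers for stronger inhibition), compound 1 gives 21 nM
Compound 2 `O=C(O)COc1ccc(Cl)cc1C#Cc1ccc2c(c1)S(=O)(=O)CC2`: in this assay compound 2 gives 23 nM

The two numbers lie within the usual scatter of each other, so compound 1 is not set apart from compound 2 on what has been measured.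

Compound 3 `Cc1ccc(S(=O)(=O)N2CCCCC2C)cc1C#Cc1cc(Cl)ccc1OCC(=O)O` has not yet been measured. It differs from compound 1 in one place: 2-methylpiperidin-1-yl in place of 4-methylpiperazin-1-yl on a sulfonyl sulfur

Within the data shown here, no measured pair shows this change, so its effect is unknown from the data. A small step toward weaker inhibition, possibly not beyond the scatter, is expected a 1.4-fold higher number from compound 1 to compound 3 (0.15 log units; within the scatter). Compound 3 is expected to give 30 nM, with a range of 8 nM to 110 nM.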

Compound 3, inhibition constant: 1.9 nM
The estimate for compound 3 lay 16-fold (1.20 log units) above the measured number, outside the stated range (below it).
By their numbers in this assay, from the lowest: compound 3; then compounds 1 and 2 (each within the scatter of the next).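

On the sulfonyl sulfur of this series, the amine is not a neutral choice: in this assay, 2-methylpiperidin-1-yl in place of 4-methylpiperazin-1-yl gives an 11-fold lower number from compound 1 to compound 3 (1.04 log units; beyond the scatter) with the core of compound 1 unchanged. The swap keeps 7 heavy atoms and a six-membered non-aromatic ring, yet the ring goes from 2 hetero atoms to 1 and the group loses its hydrogen-bond acceptor. Nothing available explains the step. The compounds shown leave open whether the ring nitrogen or the methyl placement carries the step. Piperidin-1-yl and morpholin-4-yl on the same sulfonyl sulfur would help separate these two changes.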